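From 4-methoxyphenyl to 3-cyanophenyl on compound 1

A few compounds are considered here, and "the series" means these few. Any claim that something is new, unique, unknown or untested is made for them only; others in the source may bear on it.

Measured so far in a functional assay on MCF7 cells (Homo sapiens) for inhibition, read by MTT assay, with a stated time of 72 h (on this read-out lower numbers stand for stronger inhibition and higher numbers for weaker inhibition), are two compounds:
Compound 1 `COc1ccc(Nc2nc(Oc3cccc(NC(=O)C=C(C)C)c3)c3sccc3n2)cc1` gives 46100 nM
Compound 2 `C/C=C/C(=O)Nc1cccc(Oc2nc(Nc3cccc(OC)c3)nc3ccsc23)c1` gives 14600 nM

Compound 1 has the higher of these two numbers, so it is the weaker inhibitor, and its gap to compound 2 lies beyond the scatter. These two differ in more than one place, so no single change can be read from them. Compound 3 `CC(C)=CC(=O)Nc1cccc(Oc2nc(Nc3cccc(C#N)c3)nc3ccsc23)c1` carries 3-cyanophenyl in place of 4-methoxyphenyl on a nitrogen on an aromatic ring. Expected in this assay is a moderate fall, a weakly grounded guess resting only on compound 2 sitting lower at 14600 nM on the scale. The expected step is a 2.3-fold lower number from compound 1 to compound 3 (0.36 log units; beyond the scatter) in this read-out. The estimated value for compound 3 is 20000 nM (range 6000 nM to 60000 nM).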

Compound 3, half-maximal inhibitory concentration: 41100 nM
For compound 3 the middle estimate is 2.1-fold (0.31 log units) below the measured one; measured number inside the range.
By their numbers in this assay, from the lowest: compound 2; then compounds 3 and 1 (each within the scatter of the next).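

Among these compounds, this is the first change that can be read in one place: in this assay, 3-cyanophenyl in place of 4-methoxyphenyl on the nitrogen gives a 1.1-fold lower number from compound 1 to compound 3 (0.05 log units; within the scatter). The number therefore does not separate these two groups at this position, and compound 1 and compound 3 read alike despite the different group. No measurement available here accounts for this result. As far as these compounds go, what 4-cyanophenyl, or a phenyl ring carrying an amine, would give on this nitrogen stays open. So does whether this match holds with a different amide chain on the core.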